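This account rests on a few compounds, and the source may have more. Where it says the series, first, only, none or still open, it means among the compounds named here.

In a functional assay on MCF7 cells (Homo sapiens) for cytotoxicity, read by LDH release, with a stated time of 48 h (a lower number here means a stronger inhibitor, a higher number a weaker inhibitor), the measured values are:
compound 1 `Cc1ccc(C(=O)c2cc(F)c(OCC(=O)NNC(=O)c3ccc(=O)oc3)c(Cl)c2)cc1` (24200 nM)
compound 2 `Cn1cnc(C(=O)NNC(=O)COc2c(F)cc(C(=O)c3ccc(F)cc3)cc2Cl)c1` (44600 nM)
compound 3 `Cn1cnc(C(=O)NNC(=O)COc2c(F)cc(C(=O)c3ccc(Cl)cc3)cc2Cl)c1` (44400 nM)

Compound 3 (44400 nM) lies within the scatter of both other compounds, so these values set no order. Compound 4 `Cc1ccc(C(=O)c2cc(F)c(OCC(=O)NNC(=O)c3cn(C)cn3)c(Cl)c2)cc1` differs from compound 3 by one change (methyl in place of chloro on an aromatic carbon), methyl in place of chloro on an aromatic carbon, para to a large group, which reads as 4-chlorophenyl to 4-methylphenyl. Among the compounds with values here, the only measured step at this place (a 1.0-fold lower number from compound 2 to compound 3 (0.00 log units; within the scatter)) is chloro in place of fluoro and lies within the scatter. Compound 1 also carries 4-methylphenyl but differs elsewhere too, and its value (24200 nM) gives no separation from compound 3. In this assay no step beyond the scatter is therefore expected (a 1.2-fold lower number from compound 3 to compound 4 (0.07 log units; within the scatter)). Compound 4 is estimated at (38000 nM), with an expected range from 20000 nM to (70000 nM).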

Compound 4, half-maximal inhibitory concentration: 9400 nM
For compound 4 the middle estimate is 4.0-fold (0.61 log units) above the measured one, and the stated range ends above it.
By their numbers in this assay, from the lowest: compound 4; then compounds 1, 3 and 2 (each within the scatter of the next).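

In this assay, within the data shown here, 4-methylphenyl in place of a para-halogenated phenyl is the first change at this position to move the number beyond the scatter (a 4.7-fold lower number from compound 3 to compound 4 (0.67 log units; beyond the scatter); a 4.7-fold lower number from compound 2 to compound 4 (0.68 log units; beyond the scatter)), whereas chloro in place of fluoro did not (a 1.0-fold lower number from compound 2 to compound 3 (0.00 log units; within the scatter)). With 4-methylphenyl held, the group on the carbonyl carbon also matters, the five-membered aromatic ring giving the lower number (a 2.6-fold lower number from compound 1 to compound 4 (0.41 log units; beyond the scatter)). No measurement here bears on the reason for these steps.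

Open, as far as these compounds go, is whether ethyl, methoxy or an amine at this position would follow methyl or the halogens.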